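The source may hold more compounds than are shown below. What is called first, only, known or untested is meant among the compounds shown, and "the series" means these compounds.

Working notes on the series. Compound 1 `N#Cc1c(-c2ccccc2)cn(-c2ccc(S(=O)(=O)Nc3nccs3)cc2)c1N` gives 3490 nM in a functional assay on MCF7 cells (Homo sapiens) for inhibition, read by sulforhodamine B assay, with a stated time of 24 h; a lower number here means a stronger inhibitor, a higher number a weaker inhibitor. Among the measured compounds shown here, compound 2 `N#Cc1c(-c2ccccc2)cn(-c2ccc(S(=O)(=O)Nc3ccccn3)cc2)c1N` gives 4600 nM in this assay, and the one change between them, a 1.3-fold higher number from compound 1 to compound 2 (0.12 log units; within the scatter), is a pyridin-2-yl in place of a 1,3-thiazol-2-yl on the sulfonamide nitrogen. Compound 3 `Nc1ncnc2c1c(-c1ccccc1)cn2-c1ccc(S(=O)(=O)Nc2nccs2)cc1`, built on a different core but carrying the same 1,3-thiazol-2-yl sulfonamide, gives 6450 nM in this assay. Compound 3 has the highest of the three numbers, but its separation from compound 2 and from compound 1 stays within the scatter, so the three compounds are not distinguished by these data.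

Compound 4 `Nc1ncnc2c1c(-c1ccccc1)cn2-c1ccc(S(=O)(=O)Nc2ccccn2)cc1` is not yet measured in this assay. It differs from compound 3 in one place: pyridin-2-yl in place of 1,3-thiazol-2-yl on a sulfonamide nitrogen. For the measured compounds named here, the only measured step that bears on this change is the one from compound 1 to compound 2, a 1.3-fold higher number from compound 1 to compound 2 (0.12 log units; within the scatter), where the same exchange on the other core moved the number by an amount within the scatter. Going by the values given here, no other step in the set touches this position.

On that basis no movement beyond the scatter is expected for the step from compound 3 to compound 4 in this assay; the expected step is a 1.2-fold higher number from compound 3 to compound 4 (0.07 log units; within the scatter). Compound 4 is therefore estimated at 7500 nM in this assay, with a range from 3500 nM to 16000 nM.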

Compound 4, half-maximal inhibitory concentration: 6340 nM
Compound 4: the middle estimate sits 1.2-fold (0.07 log units) above what was measured; the measured number falls inside the stated range.
By their numbers in this assay, from the lowest: compounds 1, 2, 4 and 3 (each within the scatter of the next).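

In this assay, the exchange of 1,3-thiazol-2-yl for pyridin-2-yl on the sulfonamide nitrogen now has a reading on a second core, a 1.0-fold lower number from compound 3 to compound 4 (0.01 log units; within the scatter), so the finding no longer rests on the core of compound 1 alone. The two readings of this change agree with each other within the scatter: the same change on two cores in this assay, a 1.3-fold higher number (0.12 log units; within the scatter) from compound 1 to compound 2 and a 1.0-fold lower number (0.01 log units; within the scatter) from compound 3 to compound 4, 1.3-fold (0.13 log units) apart, within the scatter of two such steps Neither reading gives the change a readable direction, so on these two cores the data do not distinguish the 1,3-thiazol-2-yl sulfonamide from the pyridin-2-yl sulfonamide, and the position accepts either aromatic ring with no change that can be read.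

From the compounds shown here alone, it remains open whether the number at this position responds to anything other than these two aromatic rings, for example a methyl group or a longer alkyl chain on the sulfonamide nitrogen, or a carboxylic acid or an amine carried on the ring itself. All four numbers also come from this assay alone, so whether the two groups remain equivalent in any other read-out cannot be told from these compounds.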